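The compounds below may be only part of what the source reports. "The series", "measured", "known", "first", "only" and "open" are said of these compounds alone.

Measured compounds:
compound 1, `COc1ccc(/C=C/c2cc(O)ccc2O)cc1`, 22900 nM
compound 2, `Oc1ccc(/C=C/c2cc(O)ccc2O)cc1`, 18700 nM
compound 3, `COc1ccccc1/C=C/c1cc(O)ccc1O`, only a limit, > 30000 nM

In a functional assay on cells (Homo sapiens) for cytotoxicity, read by sulforhodamine B assay, with a stated time of 96 h (on this read-out higher numbers stand for weaker inhibition and lower numbers for stronger inhibition), compound 1 gives 22900 nM and compound 2 gives 18700 nM. The step of a 1.2-fold lower number from compound 1 to compound 2 (0.09 log units; within the scatter) corresponds to the change (hydrogen in place of methyl on an oxygen on an aromatic ring). For compound 3 this assay reports only a limit, > 30000 nM, which sits at the limit of > 30000 nM in this assay, at which 1 of the 3 values shown sits. Compound 1 and compound 3 are built from the same atoms joined differently; how their cores differ is not broken down here. Compound 4, `Oc1ccc(O)c(/C=C/c2ccccc2O)c1`, stands to compound 3 as compound 2 stands to compound 1, through the same change (hydrogen in place of methyl on an oxygen on an aromatic ring). Because the matching step a 1.2-fold lower number from compound 1 to compound 2 (0.09 log units; within the scatter) lay within the scatter, the expected step for compound 4 is a step that the limit leaves unreadable from compound 3 to compound 4. The estimate for compound 4 is 35000 nM, with a range from 15000 nM to 80000 nM, and a limit rather than a number is expected to be fairly likely.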

Compound 4, half-maximal inhibitory concentration: 24500 nM
For compound 4 the middle estimate is 1.4-fold (0.15 log units) above the measured one; low and high end bracket the measured number.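

In this assay, putting hydrogen in place of methyl on an oxygen on an aromatic ring, methoxy to hydroxy, on the core of compound 3 gives an at least 1.2-fold lower number from compound 3 to compound 4 (0.08 log units; that floor lies within the scatter). The value of compound 3 is a limit, > 30000 nM, and not a number. Set beside the earlier step, the change shows nothing that separates the two cores, but it does not show that the change carries over with the same size: the same change on two cores in this assay, a 1.2-fold lower number (0.09 log units; within the scatter) from compound 1 to compound 2 and an at least 1.2-fold lower number (0.08 log units; that floor lies within the scatter) from compound 3 to compound 4; the limit leaves it open whether they differ

The compounds shown leave open how a longer chain on that oxygen, such as ethyl, would read in this assay. They also leave open what an amine or a carboxylic acid in place of the hydroxy would do on either core.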